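The source may hold more compounds than are shown below. What is called first, only, known or untested is meant among the compounds shown, and "the series" means these compounds.

In a functional assay on NCI-H23 cells (Homo sapiens) for antiproliferative activity, read by sulforhodamine B assay (on this read-out lower numbers stand for stronger inhibition of growth and higher numbers for weaker inhibition of growth), compound 3 `CC(C)(C)CCOc1cccc(O)c1C(=O)/C=C/c1ccc(O)cc1` gives 3130 nM, the lowest of the two numbers in hand. Compound 2 `CC(C)(C)CCOc1cccc(O)c1C(=O)/C=C/c1ccc(C(=O)O)cc1` gives 4770 nM, and the step of a 1.5-fold lower number from compound 2 to compound 3 (0.18 log units; within the scatter). Compound 1 `O=C(/C=C/c1ccc(O)cc1)c1c(O)cccc1OCc1ccccc1` gives > 30000 nM, which is a limit of this assay and not a number (the limit of > 30000 nM in this assay, at which 1 of the 3 values shown sits). The step of an at least 9.5-fold lower number from compound 1 to compound 3 (0.98 log units; beyond the scatter) concerns the neopentyl in place of phenyl, not the hydroxy. Compound 4 `CC(C)(C)CCOc1cccc(O)c1C(=O)/C=C/c1ccc(S(N)(=O)=O)cc1` carries the change (sulfamoyl in place of hydroxy on an aromatic carbon). Among the compounds with values here, the only measured step at the same aromatic carbon, a 1.5-fold lower number from compound 2 to compound 3 (0.18 log units; within the scatter), stayed within the scatter, so for compound 4 in this assay no move beyond the scatter is expected, and the step of a 1.3-fold higher number from compound 3 to compound 4 (0.11 log units; within the scatter) is the estimated outcome. Compound 4 is expected at 4000 nM, between 1500 nM and 11000 nM.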

Compound 4, concentration for 50% growth inhibition: 2950 nM
Beside the measured number, compound 4's estimate is 1.4-fold (0.13 log units) above it; the measured number falls inside the stated range.
By their numbers in this assay, from the lowest: compounds 4, 3 and 2 (each within the scatter of the next). At a limit, above all of these: compound 1.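

At the aromatic carbon para to a large group, sulfamoyl now joins hydroxy and carboxy with no move beyond the scatter in this assay (a 1.1-fold lower number from compound 3 to compound 4 (0.03 log units; within the scatter); a 1.6-fold lower number from compound 2 to compound 4 (0.21 log units; within the scatter)). The earlier compounds shown here offered one such step at this carbon; compound 2, compound 3 and compound 4 now all lie within the scatter of one another, so none ranks above another. Nothing shown gives a reason for this flat response.

Open, as far as these compounds go, is whether an amine or a methoxy at this carbon would stay within the same scatter. Also open, from the compounds shown here alone, is whether a longer chain in place of neopentyl would shift the numbers with sulfamoyl present.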